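One Ring Stereocentre Inverted: Compound 3 to Compound 4

A few compounds are considered here, and "the series" means these few. Any claim that something is new, unique, unknown or untested is made for them only; others in the source may bear on it.

Compound 1 `CC1=C(O)[C@@H](C/C(C)=C\CC[C@H](C)/C=C/C=C(\C)CCCc2ccoc2)OC1=O` gives 5.6 ug/mL in a functional assay on SK-MEL-2 cells (Homo sapiens) for cytotoxicity; on this read-out lower numbers stand for an effect already at smaller amounts and higher numbers for an effect only at larger amounts of compound.
Compound 2 `CC1=C(O)[C@@H](C/C(C)=C\CC[C@H](C)/C=C/C=C(\C)CCCC2=CCN(CCC(C)C)C2=O)OC1=O` gives 3.4 ug/mL in this assay.
Compound 3 `CCC(C)CN1CC=C(CCC/C(C)=C/C=C/[C@@H](C)CC/C=C(/C)C[C@@H]2OC(=O)C(C)=C2O)C1=O` gives 3.8 ug/mL in this assay.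

Compound 3 has the second highest of the three numbers; its neighbours, compound 2 and compound 1, both lie within the scatter of it. Compound 4 `CCC(C)CN1CC=C(CCC/C(C)=C/C=C/[C@@H](C)CC/C=C(/C)C[C@H]2OC(=O)C(C)=C2O)C1=O` differs from compound 3 only in stereochemistry: the two compounds have the same atoms and bonds; at least one stereo element is drawn with a configuration in one of them and without one in the other: 1 of 6 stereo elements differ; a stereocentre at a saturated ring carbon is drawn S in compound 3 and R in compound 4. Within the data shown here, the single measured step, a 1.6-fold lower number from compound 1 to compound 2 (0.22 log units; within the scatter), concerns a different part of the molecule and says nothing about a stereocentre on the saturated ring carbon, so no measured step bears on this change. Nothing in the data points to a direction, and a step of no change at the digits printed from compound 3 to compound 4 (within the scatter) is therefore expected, none beyond the scatter. Compound 4 is estimated at 3.8 ug/mL, within 1.5 ug/mL to 10 ug/mL.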

Compound 4, concentration for half-maximal effect: 15.9 ug/mL
Estimate against measurement, compound 4: 4.2-fold (0.62 log units) below; measured number outside the range, above it.
By their numbers in this assay, from the lowest: compounds 2, 3 and 1 (each within the scatter of the next); then compound 4.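

In this assay, among these compounds, the configuration at this saturated ring carbon turns out to count on its own, with a 4.2-fold higher number from compound 3 to compound 4 (0.62 log units; beyond the scatter) as the first step at this position beyond the scatter. The other two steps, a 4.7-fold higher number from compound 2 to compound 4 (0.67 log units; beyond the scatter) and a 2.8-fold higher number from compound 1 to compound 4 (0.45 log units; beyond the scatter), are also beyond the scatter, so compound 4 stands apart from compounds 1 and 2, although the step between those two lay within it. The only thing on record to set against the stereochemical step is this: the fact that one of compounds 3 and 4 is drawn with a defined configuration and the other without, at the place where they differ.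

On these data alone, whether the ring configuration carries the same weight with the furan or the isobutyl end stays open. So does the effect of a methyl group in place of the hydrogen on this ring carbon.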